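This account rests on a few compounds, and the source may have more. Where it says the series, first, only, none or still open, it means among the compounds named here.

Series notes. Compound 1 `CC(O)(C[S+]([O-])c1ccc(F)c(F)c1)C(=O)Nc1ccc([N+](=O)[O-])cc1C(F)(F)F` in a functional assay on DU-145 cells (Homo sapiens) for antiproliferative activity (a lower number here means a stronger inhibitor, a higher number a weaker inhibitor), gives only a limit, > 100000 nM; > 100000 nM (2 entries). Compound 2 `CC(O)(C[S+]([O-])c1ccccn1)C(=O)Nc1ccc([N+](=O)[O-])cc1C(F)(F)F` in this assay likewise returns only a limit, > 100000 nM. Compound 3 `CC(O)(C[S+]([O-])c1ccc(OC(F)(F)F)cc1)C(=O)Nc1ccc([N+](=O)[O-])cc1C(F)(F)F` in this assay also returns a limit, > 100000 nM. Among the measured compounds shown here, the one recorded step, a step that the two limits leave unreadable from compound 2 to compound 3, cannot be read because both ends sit at the limit. Compound 3 therefore stands where most of the series stands, at the limit of > 100000 nM in this assay, at which 2 of the 3 values shown sit. Compound 4 `CC(O)(C[S+]([O-])c1ccccc1OC(F)(F)F)C(=O)Nc1ccc([N+](=O)[O-])cc1C(F)(F)F` differs from compound 3 by 2-(trifluoromethoxy)phenyl in place of 4-(trifluoromethoxy)phenyl on a sulfur. For the measured compounds named here, no measured step bears on this change, and the single recorded step gives no readable size. A further limit is expected for compound 4. The step from compound 3 to compound 4 is estimated as a step that the limit leaves unreadable from compound 3 to compound 4. Compound 4 is expected at 150000 nM, within 50000 nM to 500000 nM.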

Compound 4, half-maximal inhibitory concentration: 31100 nM
For compound 4 the middle estimate is 4.8-fold (0.68 log units) above the measured one; the measured number lies below the stated range.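

In this assay, 2-(trifluoromethoxy)phenyl in place of 4-(trifluoromethoxy)phenyl on the sulfur gives an at least 3.2-fold lower number from compound 3 to compound 4 (0.50 log units; beyond the scatter), so the same atoms, joined differently, give a readable separation. In place of pyridin-2-yl, the same group gives an at least 3.2-fold lower number from compound 2 to compound 4 (0.50 log units; beyond the scatter). Compound 4 is the only compound here with a number rather than a limit, and the others rest at that limit: the limit of > 100000 nM in this assay, at which 2 of the 4 values shown sit.

From the compounds shown here alone, the full size of both steps stays open, since each starts from a limit. Also open, going by these compounds, is whether 2-methoxyphenyl or 2-chlorophenyl on the sulfur would likewise give a number.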